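This account rests on a few compounds, and the source may have more. Where it says the series, first, only, none or still open, it means among the compounds named here.

In a functional assay on OVCAR-3 cells (Homo sapiens) for inhibition, read by MTT assay, with a stated time of 24 h (a higher number here means a weaker inhibitor, a lower number a stronger inhibitor), compound 1 (`CC1(C)[C@H]2CC[C@]1(C)N(Cc1cn(-c3ccccc3Cl)nn1)C(=O)C2`) gives 40 nM and compound 2 (`CC1(C)[C@H]2CC[C@]1(C)N(Cc1cn(-c3cccc(Cl)c3)nn1)C(=O)C2`) gives 50 nM as its reading, so compound 2 stands level with compound 1 within the scatter. Compound 3 (`CC1(C)[C@H]2CC[C@]1(C)N(Cc1cn(-c3ccc(Br)cc3)nn1)C(=O)C2`) differs from compound 2 on an aromatic nitrogen, with 4-bromophenyl in place of 3-chlorophenyl (4-bromophenyl in place of 3-chlorophenyl on an aromatic nitrogen). Among the measured compounds shown here, the one measured step that bears on this is a 1.3-fold higher number from compound 1 to compound 2 (0.10 log units; within the scatter) for 3-chlorophenyl in place of 2-chlorophenyl, so no change beyond the scatter is expected in this assay here. For the measured compounds named here, no compound with 4-bromophenyl has a measured value yet, so the estimate stays broad. The estimate means no change at the digits printed from compound 2 to compound 3 (within the scatter) as the expected step. Compound 3 is expected at 50 nM (estimated range 18 nM to 140 nM).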

Compound 3, half-maximal inhibitory concentration: 140 nM
Estimate against measurement, compound 3: 2.8-fold (0.45 log units) below; the range from low to high includes it.
By their numbers in this assay, from the lowest: compounds 1 and 2 (each within the scatter of the next); then compound 3.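

Moving the chlorine around the phenyl ring left the reading within the scatter, but 4-bromophenyl on the aromatic nitrogen gives the first clear shift at this position: a 2.8-fold higher number from compound 2 to compound 3 (0.45 log units; beyond the scatter), and a 3.5-fold higher number from compound 1 to compound 3 (0.54 log units; beyond the scatter). The phenyl group here can therefore weaken the compound measurably, though it need not do so with every halogen placement. Nothing available explains this weakening.

The halogen and its ring position change together in this step, so their contributions cannot be separated. On these data alone, a 4-chlorophenyl or 3-bromophenyl compound would separate them, and an unsubstituted phenyl or 4-aminophenyl group remains untested here.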